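Changing the Ring Group on the Amide Carbonyl

The source may report more compounds than this note shows. Statements on the series, on what has been measured and on what is new or still open speak of the compounds shown alone.

Compound 1, `O=C(C1CCC1)N1CC(c2nc(-c3cccc(Cl)c3)no2)C1`, in an assay on HEK293 cells for positive allosteric modulation of metabotropic glutamate receptor 5 (Homo sapiens), read by FLIPR (on this read-out higher numbers stand for an effect only at larger amounts of compound and lower numbers for an effect already at smaller amounts), reaches only the assay's limit of > 10000 nM.
Compound 2, `O=C(C1CCC2(CCC2)CC1)N1CC(c2nc(-c3cccc(Cl)c3)no2)C1`, gives 1100 nM in this assay.
Compound 3, `O=C([C@@H]1CC2CCC1C2)N1CC(c2nc(-c3cccc(Cl)c3)no2)C1`, is not yet measured.

Going by the values given here, compound 2 holds the only real number here; the value for compound 1 is a limit rather than a number. The change to compound 3 is a group of 7 heavy atoms (7 carbon; 2 five-membered non-aromatic rings of carbon only) in place of a group of 9 heavy atoms (9 carbon; one four-membered non-aromatic ring of carbon only, one six-membered non-aromatic ring of carbon only), on a carbonyl carbon, on a carbonyl carbon whose other neighbours are an amide-type nitrogen in a ring. Among the compounds with values here, one measured step bears on it: an at least 9.0-fold lower number from compound 1 to compound 2 (0.95 log units; beyond the scatter), which shows that a larger ring group at this carbonyl helps compared with the small four-membered ring alone. The group entering in compound 3 is smaller than the one it replaces but larger than that of compound 1, so a modest loss, or no change beyond the scatter, is expected. For compound 3 the expected value in this assay is 2500 nM, between 800 nM and 8000 nM, meaning an expected step of a 2.3-fold higher number from compound 2 to compound 3 (0.36 log units; beyond the scatter).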

Compound 3, half-maximal effective concentration: 98 nM
Compound 3: the middle estimate sits 26-fold (1.41 log units) above what was measured, outside the stated range (below it).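

In this assay, replacing the group with a four-membered and a six-membered ring by the smaller group with two five-membered rings gives an 11-fold lower number from compound 2 to compound 3 (1.05 log units; beyond the scatter), so at this carbonyl carbon more heavy atoms do not simply mean a lower number. Set against the lone four-membered ring, the same group gives an at least 100-fold lower number from compound 1 to compound 3 (2.00 log units; beyond the scatter), so the three compounds do not line up by heavy-atom count: the middle-sized group gives the lowest number. That step is only a bound, since one end of it is a limit of the assay: the limit of > 10000 nM in this assay, at which 1 of the 3 values shown sits.

Which feature of the two five-membered rings matters stays open, including the role of the one defined stereocentre. Also open, on these data alone, is how a phenyl ring, or a ring carrying an amine, would fare on this carbonyl carbon.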